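Hydroxyphenyl-substituted pyridine series: moving a hydroxy from meta to para

This account rests on a few compounds, and the source may have more. Where it says the series, first, only, none or still open, it means among the compounds named here.

Measured so far in a functional assay on HeLa cells (Homo sapiens) for inhibition; a lower number here means a stronger inhibitor, a higher number a weaker inhibitor:
Compound 1, `Oc1ccc(-c2cc(-c3cccc(F)c3)cc(-c3cccc(O)c3)n2)cc1`: compound 1 gives 14200 nM.
Compound 2, `Oc1ccc(-c2cc(-c3cccc(F)c3)cc(-c3ccc(O)cc3)n2)cc1`: compound 2 gives > 50000 nM, which is a limit of the assay and not a number.
Compound 3, `Oc1cccc(-c2cc(-c3cccc(OC(F)(F)F)c3)cc(-c3ccccc3O)n2)c1`: compound 3 gives 14900 nM.

Compound 1 and compound 2 differ by 4-hydroxyphenyl in place of 3-hydroxyphenyl on an aromatic carbon. The step of an at least 3.5-fold higher number from compound 1 to compound 2 (0.54 log units; beyond the scatter), where the value of compound 2 is one of the values sitting at the limit of > 50000 nM in this assay, at which 1 of the 3 values shown sits. Compound 3 stands within the scatter of compound 1; how their cores differ is not broken down here.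

Compound 4, `Oc1ccc(-c2cc(-c3cccc(OC(F)(F)F)c3)cc(-c3ccccc3O)n2)cc1`, is not yet measured. It differs from compound 3 by 4-hydroxyphenyl in place of 3-hydroxyphenyl on an aromatic carbon. This is the same kind of change as from compound 1 to compound 2, but the surroundings differ: in compound 1 the place is meta to a 3-fluorophenyl group and meta to a 4-hydroxyphenyl group, in compound 3 it is meta to a 2-hydroxyphenyl group and meta to a large group.

On the strength of the step from compound 1 to compound 2, compound 4 is expected to show a 3.4-fold higher number from compound 3 to compound 4 (0.53 log units; beyond the scatter) in this assay. The estimate for compound 4 is 50000 nM, between 25000 nM and 150000 nM, with a fair chance that only a limit is reported.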

Compound 4, half-maximal inhibitory concentration: > 50000 nM
Compound 4: no number, only a limit (the forecaster's own chance of this, stated with the estimate: 55%); the middle value sits exactly at the limit.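

In this assay compound 4 gives > 50000 nM, which is a limit of the assay and not a number. Placing 4-hydroxyphenyl where 3-hydroxyphenyl stood gives an at least 3.3-fold higher number from compound 3 to compound 4 (0.52 log units; beyond the scatter), so the change carries over in the same direction to the second core, and the result on the first core is not specific to that core: the same change on two cores in this assay, an at least 3.5-fold higher number (0.54 log units; beyond the scatter) from compound 1 to compound 2 and an at least 3.3-fold higher number (0.52 log units; beyond the scatter) from compound 3 to compound 4; the limit leaves it open whether they differ The true size of each step remains unknown, so these data do not show that the two cores respond equally, or how far either step extends, as compound 2 and compound 4 both end at the same limit: the limit of > 50000 nM in this assay, at which 2 of the 4 values shown sit.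

On these data alone, two cores are a small base, and it remains open whether the same change would reduce inhibition on a core carrying other groups in place of 3-fluorophenyl or 3-trifluoromethoxyphenyl. Also open, as far as these compounds go, is whether an amine or a carboxylic acid in place of the hydroxy of the 4-hydroxyphenyl group would give a readable number in this assay.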